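Chloro in place of phenyl: compound 3 to compound 4

A few compounds are considered here, and "the series" means these few. Any claim that something is new, unique, unknown or untested is made for them only; others in the source may bear on it.

Compound 1 `C=C(Br)C(=O)Nc1ccc2[nH]c(C(=O)O)cc2c1` gives 5600 nM in a functional assay on K562 cells (Homo sapiens) for antiproliferative activity; a lower number here means a stronger inhibitor, a higher number a weaker inhibitor.
Compound 2 `C=C(Br)C(=O)Nc1ccc2oc(C(=O)NCCNC(=O)c3cc(OCC4(c5ccc(Cl)cc5)CC(=C)C(=O)O4)nn3C)cc2c1` gives 710 nM in this assay.
Compound 3 `C=C1CC(COc2cc(C(=O)O)n(C)n2)(c2ccc(-c3ccccc3)cc2)OC1=O` is reported only as a limit, > 10000 nM, in this assay.

Compound 3 thus stands at the edge of what this assay resolves; the relevant observation is the limit of > 10000 nM in this assay, at which 1 of the 3 values shown sits. Compound 4 `C=C1CC(COc2cc(C(=O)O)n(C)n2)(c2ccc(Cl)cc2)OC1=O` differs from compound 3 in one place: chloro in place of phenyl on an aromatic carbon. Going by the values given here, no measured pair shows this change on its own, so its size is not known from the series. Among the compounds with values here, compound 2 also carries a chloro group, within a much larger structure, and its value in this assay is the lowest of the three, but it differs from compound 4 in many places and no step is drawn between them. The expected step in this assay is a step that the limit leaves unreadable from compound 3 to compound 4, a change not beyond the usual scatter. Compound 4 is estimated at 15000 nM, with a range from 4000 nM to 50000 nM, and a fair chance that only a limit is again reported.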

Compound 4, half-maximal inhibitory concentration: > 10000 nM
Compound 4: only a limit was reported; the forecaster's own chance of this, stated with the estimate: 60%; the middle value is on the limit's open side.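

Going by these compounds alone, compound 3 and compound 4 are both reported only as limits in this assay, so no step between them can be read: the limit of > 10000 nM in this assay, at which 2 of the 4 values shown sit. The compounds shown leave open how far chloro in place of phenyl on an aromatic carbon shifts the value in this assay.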